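The compounds below may be only part of what the source reports. "The series", "measured", "known", "first", "only" and "open" are said of these compounds alone.

Measured compounds:
Compound 1, `CCCCCCCc1cn(C(c2ccccc2)c2cc3cc(Br)ccc3nc2OC)nn1`: in an ADME assay on SK-OV-3 cells (Homo sapiens) for cytotoxicity, read by sulforhodamine B assay, with a stated time of 48 h, tested at 10 uM (on this read-out lower numbers stand for less inhibition and higher numbers for more inhibition at the one concentration tested (going by the name of the read-out)), compound 1 gives 10.5%.
Compound 2, `CCCCCCc1cn(C(c2ccccc2)c2cc3cc(Br)ccc3nc2OC)nn1`: in this assay compound 2 gives 7.17%.

Among the compounds with values here, of the two numbers, the one for compound 2 is the lower on paper, but the gap to compound 1, a number 3.3 percentage points lower from compound 1 to compound 2 (within the scatter), lies within the scatter, so the two compounds cannot be told apart on this read-out. Both sit near the bottom of the scale.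

Compound 3, `COc1nc2ccc(Br)cc2cc1C(c1ccccc1)n1cc(-c2ccccc2)nn1`, has not yet been measured. It differs from compound 2 by phenyl in place of hexyl on an aromatic carbon. Within the data shown here, the only measured step, from compound 1 to compound 2, concerns a change on the saturated chain and says nothing about replacing that chain with an aromatic ring; no step bearing on the present change is available. With both measured compounds sitting low and within the scatter of each other, nothing in the data points to a move beyond the scatter in either direction. Compound 3 is therefore expected to give roughly 10%, within about 0% to 30%, and the expected step of a number 2.8 percentage points higher from compound 2 to compound 3 (within the scatter) is small and uncertain in sign.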

Compound 3, a percentage reported as inhibition, at one concentration (the size of the read-out at that concentration, not a potency): 13.7%
Beside the measured number, compound 3's estimate is 3.7 percentage points below it; low and high end bracket the measured number.
By their numbers in this assay, from the lowest: compounds 2, 1 and 3 (each within the scatter of the next).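

In this assay, the position on the aromatic carbon of the five-membered aromatic ring with 3 nitrogen now carries a phenyl ring rather than a saturated chain, and phenyl in place of hexyl gives a number 6.5 percentage points higher from compound 2 to compound 3 (within the scatter) while phenyl in place of heptyl gives a number 3.2 percentage points higher from compound 1 to compound 3 (within the scatter) on the same read-out. The earlier compounds shown here showed only that trimming the chain by one carbon could not be told apart on this read-out; these steps extend that to a much larger change in the kind of group, from an open chain to one six-membered aromatic ring of carbon only. Across these three compounds, then, exchanging chain for ring at this position gives no step beyond the scatter, and nothing at hand offers an explanation of this result.

Still open, going by these compounds, is whether an amine, a carboxylic acid or a much longer chain at this position would give a step beyond the scatter in this assay at the one concentration tested. Also open, on these data alone, is whether a phenyl ring bearing a methoxy group or a halogen would separate from the unsubstituted phenyl of compound 3.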